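Trifluoromethyl ketone in place of thiocarbamate on the piperidine nitrogen

The source may report more compounds than this note shows. Statements on the series, on what has been measured and on what is new or still open speak of the compounds shown alone.

Measured compounds:
compound 1 `Cc1nc(S(C)(=O)=O)ccc1Oc1ncnc(OC2CCN(C(=O)OC(C)(C)C(F)(F)F)CC2)c1F`, 6.53 nM
compound 2 `Cc1nc(S(C)(=O)=O)ccc1Oc1ncnc(OC2CCN(C(=O)SC(C)(C)C)CC2)c1F`, 4.83 nM

Two compounds share a core and differ only in the group on the carbonyl carbon attached to the ring nitrogen. In a functional assay on isolated protein for inhibition of Glucose-dependent insulinotropic receptor (Homo sapiens), read by HTRF and cAMP accumulation (a lower number here means that less compound is needed, a higher number that more compound is needed for the effect), compound 1 gives 6.53 nM, and compound 2 gives 4.83 nM. The step of a 1.4-fold lower number from compound 1 to compound 2 (0.13 log units; within the scatter) shows that swapping one branched group for another at this position leaves the result essentially unchanged. Compound 2 holds the lowest of the two numbers, though its gap to compound 1 is within the scatter.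

Compound 3 `Cc1nc(S(C)(=O)=O)ccc1Oc1ncnc(OC2CCN(C(=O)C(F)(F)F)CC2)c1F` carries the change (trifluoromethyl in place of (tert-butyl)sulfanyl on a carbonyl carbon). This removes a branched substituent entirely and puts a small fluorinated group in its place, a larger change than the measured step. Going by the values given here, the one measured step bears on it only loosely. The expectation for compound 3 is a moderate rise, a 3.1-fold higher number from compound 2 to compound 3 (0.49 log units; beyond the scatter), giving an estimated 15 nM with a range of 5 nM to 50 nM.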

Compound 3, half-maximal effective concentration: 151 nM
The estimate for compound 3 lay 10-fold (1.00 log units) below the measured number; the measured number lies above the stated range.
By their numbers in this assay, from the lowest: compounds 2 and 1 (each within the scatter of the next); then compound 3.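

In this assay there is a 31-fold higher number from compound 2 to compound 3 (1.50 log units; beyond the scatter) and also a 23-fold higher number from compound 1 to compound 3 (1.36 log units; beyond the scatter) once trifluoromethyl sits on the carbonyl carbon, so this position is not indifferent to its group, as the first two compounds alone might have suggested. Fluorine as such does not go with the low numbers: compound 1 also carries a trifluoromethyl, further out within its 1-methyl-1-(trifluoromethyl)ethoxy group, and it stays within the scatter of compound 2. No measurement is available that explains the rise.

In compound 3, the branched carbons and the sulfur or oxygen atom attached to the carbonyl carbon are lost together, and these compounds cannot separate the two. A tert-butyl, a methyl or a dimethylamino group on the carbonyl carbon would help to tell them apart.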